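From Formyl to Acetyl: A Small Change

The compounds below may be only part of what the source reports. "The series", "measured", "known", "first", "only" and "open" are said of these compounds alone.

Compound 1 `CCC(=O)N(c1ccc(Cl)cc1)C1CCCCC1N(C)C`: 17 mg/kg
Compound 2 `CN(C)C1CCCC1N(C=O)c1ccccc1`: > 50 mg/kg

Both results come from a functional assay on the whole organism for antagonist activity, with Mus musculus as the target; on this read-out higher numbers stand for an effect only at larger amounts of compound and lower numbers for an effect already at smaller amounts. For compound 2 the reported > 50 mg/kg is a limit of the assay and not a number. Compound 2 therefore has no exact place on the scale. Next comes compound 3 `CC(=O)N(c1ccccc1)C1CCCC1N(C)C`, which is compound 2 with one structural change: methyl in place of hydrogen on a carbonyl carbon. In words, this puts methyl in place of hydrogen on a carbonyl carbon, turning formyl into acetyl. Going by the values given here, no measured pair shows what this change does, so any expectation is loose. A modest shift toward smaller doses is expected, and it may not exceed the usual scatter; the estimated change is an at least 1.2-fold lower number from compound 2 to compound 3 (0.09 log units; that floor lies within the scatter). Among the compounds with values here, the only exact value, 17 mg/kg for compound 1, suggests that a result in this general range is plausible. It is also quite possible that compound 3 will again return only a limit. For compound 3 the estimated value is 40 mg/kg, with an expected range from 15 mg/kg to 100 mg/kg.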

Compound 3, dose for half-maximal effect: 9 mg/kg
For compound 3 the middle estimate is 4.4-fold (0.65 log units) above the measured one; measured number outside the range, below it.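

In this assay, putting methyl in place of hydrogen on a carbonyl carbon, the change from formyl to acetyl, gives an at least 5.5-fold lower number from compound 2 to compound 3 (0.74 log units; beyond the scatter). Going by these compounds alone, this is the first measured pair in which only one place differs, and it shows that the carbonyl carbon, whose other neighbour here is an amide-type nitrogen, is a place where so small a change can move the result beyond the usual scatter. The real size of the step remains unknown, and only its lower bound can be read, because compound 2 stands at a limit of the assay and not at a number: the limit of > 50 mg/kg in this assay, at which 1 of the 3 values shown sits.

Compound 1 differs from compound 3 in more than one place, so it cannot show how much of its own result comes from the group on its carbonyl carbon. Whether a longer chain such as propyl, or a ring such as cyclopropyl, in place of that methyl would lower the number further or raise it again remains open, and the compounds shown give no hint of the direction.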